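Changing the ring on the amide carbonyl of compound 2

The source may report more compounds than this note shows. Statements on the series, on what has been measured and on what is new or still open speak of the compounds shown alone.

Measured compounds:
- compound 1, `CCN(CC)S(=O)(=O)c1ccc(S(=O)(=O)N2CCC[C@@H](C(=O)N[C@H]3CC[C@H](OC)CC3)C2)cc1`, in a functional assay on MIA PaCa-2 cells (Homo sapiens) for inhibition, read by MTT assay, with a stated time of 3 days (a lower number here means a stronger inhibitor, a higher number a weaker inhibitor), gives 2290 nM
- compound 2, `CCN(CC)S(=O)(=O)c1ccc(S(=O)(=O)N2CCC[C@@H](C(=O)N3CC[C@@H](OC)C3)C2)cc1`, in this assay gives 1070 nM

For the measured compounds named here, compound 2 holds the lowest of the two numbers, and the one step available, a 2.1-fold lower number from compound 1 to compound 2 (0.33 log units; beyond the scatter), shows a modest gain when the amide of compound 1 is closed into a ring. Compound 3, `CCN(CC)S(=O)(=O)c1ccc(S(=O)(=O)N2CCC[C@@H](C(=O)N3CCC(C(F)F)CC3)C2)cc1`, keeps that cyclic amide and alters only its ring: 4-(difluoromethyl)piperidin-1-yl in place of 3-methoxypyrrolidin-1-yl on a carbonyl carbon. Going by the values given here, no measured step tells how this particular exchange plays out; the step from compound 1 to compound 2 concerns a different part of the amide and bears on it only loosely. With nothing in the data pointing either way, the change is expected to stay within the scatter, giving a 1.1-fold lower number from compound 2 to compound 3 (0.03 log units; within the scatter). Compound 3 is therefore estimated at 1000 nM in this assay, with a range from 400 nM to 2500 nM.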

Compound 3, half-maximal inhibitory concentration: 140 nM
Compound 3: the middle estimate sits 7.1-fold (0.85 log units) above what was measured; measured number outside the range, below it.
By their numbers in this assay, from the lowest: compound 3; then compound 2; then compound 1.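

In this assay the group on this carbonyl carbon has a much larger effect than the first step showed, since 4-(difluoromethyl)piperidin-1-yl in place of 3-methoxypyrrolidin-1-yl gives a 7.6-fold lower number from compound 2 to compound 3 (0.88 log units; beyond the scatter) and the same group in place of (4-methoxycyclohexyl)amino gives a 16-fold lower number from compound 1 to compound 3 (1.21 log units; beyond the scatter) in the same read-out. So a cyclic amide alone does not set the number here, as compound 2 and compound 3 both carry one and still differ clearly. Nothing at hand accounts for the gain.

The exchange alters ring size, the methoxy group, the fluorines and the defined stereocentre all at once, and the compounds shown do not separate these changes. Plain piperidin-1-yl, 4-methoxypiperidin-1-yl and 4-(trifluoromethyl)piperidin-1-yl on the same carbonyl carbon remain open.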